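From Ethyl to Bromophenyl: Expected Growth Inhibition

The source may report more compounds than this note shows. Statements on the series, on what has been measured and on what is new or still open speak of the compounds shown alone.

Of the compounds shown here, three sharing one core have been measured in a functional assay on HCT-116 cells (Homo sapiens) for inhibition, read by sulforhodamine B assay, with a stated time of 48 h, tested at 50 uM; a higher number here means more inhibition of growth at the concentration tested, a lower number less inhibition of growth. Compound 1 `CCOc1ccc([C@@H]2CC(=O)c3cc(CC=C(C)C)c(OC)cc3O2)cc1` gives 65%, the lowest of the three numbers. Compound 3 `COc1cc2c(cc1CCC(C)C)C(=O)C[C@@H](c1ccc(O)cc1)O2` gives 77%, which lies beyond the scatter above compound 1, and compound 2 `COc1cc2c(cc1CC=C(C)C)/C(=N/O)C[C@@H](c1ccc(O)cc1)O2` gives 99%, further still above compound 1. Compound 4 `COc1cc2c(cc1CC=C(C)C)C(=O)C[C@@H](c1ccc(Oc3ccc(Br)cc3)cc1)O2` has not yet been measured. It differs from compound 1 in a single place: 4-bromophenyl in place of ethyl on an oxygen on an aromatic ring. Within the data shown here, no measured pair shows what this exchange does, so its effect cannot be read from the data at hand. A modest rise in this assay is expected, though one that may stay within the scatter, and the expected step is a number 7 percentage points higher from compound 1 to compound 4 (within the scatter). Compound 4 is therefore expected to give about 72% in this assay, with a range from 45% to 92%.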

Compound 4, percent growth inhibition at one concentration: 76%
Compound 4: middle estimate off by 4 percentage points, on the low side, within the range that was stated.
By their numbers in this assay, from the lowest: compound 1; then compounds 4 and 3 (each within the scatter of the next); then compound 2.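

In this assay, 4-bromophenyl in place of ethyl on this oxygen gives a number 11 percentage points higher from compound 1 to compound 4 (beyond the scatter) at the concentration tested. This position on the shared core therefore accepts a much bigger group, one that adds an aromatic ring, with no loss of growth inhibition. Nothing available explains why the number rises.

The compounds shown leave open whether the added ring or the bromine matters here, a question that plain phenyl on the same oxygen could help settle. On these data alone, how a carboxylic acid or an amine on this ring would read also remains open.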